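The compounds below may be only part of what the source reports. "The series", "measured", "known", "first", "only" and "open" are said of these compounds alone.

Compound 1, `O=C(N1CCC(F)CC1)N1CC(c2nc(-c3cccc(Cl)c3)no2)C1`, carries the shared core of the set and was read in an assay on HEK293 cells for negative allosteric modulation of metabotropic glutamate receptor 5 (Homo sapiens), read by FLIPR; on this read-out lower numbers stand for stronger inhibition and higher numbers for weaker inhibition. In this assay compound 1 gives > 10000 nM, which is a limit of the assay rather than a number. Compound 1 therefore stands at the weak end of what has been measured, at the limit of > 10000 nM in this assay, at which 1 of the 2 values shown sits. Among the measured compounds shown here, the other measured compound, compound 2, `Cc1cccc(-c2noc(C3CN(S(=O)(=O)c4ccc(F)cc4)C3)n2)c1`, differs from compound 1 in more than one place, so no single step joins the two; in this assay compound 2 gives 950 nM. Compound 3, `O=C(C1CCCO1)N1CC(c2nc(-c3cccc(Cl)c3)no2)C1`, has not yet been measured. It differs from compound 1 in one place: oxolan-2-yl in place of 4-fluoropiperidin-1-yl on a carbonyl carbon. For the measured compounds named here, no step between measured compounds bears on this change, and only a limit is known for compound 1. A modest move toward stronger inhibition is expected from compound 1 to compound 3 an at least 1.4-fold lower number from compound 1 to compound 3 (0.15 log units; that floor lies within the scatter), one that may not rise beyond the usual scatter. Compound 3 is estimated at 7000 nM in this assay, with an expected range from 1500 nM to 30000 nM.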

Compound 3, half-maximal inhibitory concentration: 890 nM
Beside the measured number, compound 3's estimate is 7.9-fold (0.90 log units) above it; measured number outside the range, below it.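

Among the compounds shown here, on a carbonyl carbon whose other neighbour is an amide-type nitrogen in a ring, oxolan-2-yl in place of 4-fluoropiperidin-1-yl gives an at least 11-fold lower number from compound 1 to compound 3 (1.05 log units; beyond the scatter), the first single-place step in this set, and it shows that this position bears strongly on the read-out in this assay. The true size of this step is not known, and what is printed is a floor, for the value of compound 1 is a limit of the assay and not a number: the limit of > 10000 nM in this assay, at which 1 of the 3 values shown sits. The change also alters several counted features at once, with 7 heavy atoms, a nitrogen, a fluorine and 0 hydrogen-bond acceptors leaving, and 5 heavy atoms, an oxygen and 1 hydrogen-bond acceptor entering, so this one step does not assign the gain to any one of them.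

On these data alone, what stays open is how much of the step belongs to the ring oxygen of oxolan-2-yl, to the five-membered ring, or to the loss of the nitrogen and fluorine of the group that leaves. Cyclopentyl, a five-membered ring with no oxygen, or morpholin-4-yl on the same carbonyl carbon would be needed to pull these apart.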